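A few compounds are considered here, and "the series" means these few. Any claim that something is new, unique, unknown or untested is made for them only; others in the source may bear on it.

Four compounds share one core and differ only in the group carried on a nitrogen of that core. Compound 1 `Cc1n[nH]c2ccc(-c3nc4cnc(N5CCN(C)CC5)cn4c3Nc3ccc(F)cc3)cc12` and compound 3 `Cc1n[nH]c2ccc(-c3nc4cnc(N5CCN(C)CC5)cn4c3Nc3ccc(Br)cc3Cl)cc12` both belong to the set, but neither has a number on the read-out: in a functional assay on CWR22R cells (Homo sapiens) for inhibition, with a stated time of 120 h, tested at 10 uM (on this read-out lower numbers stand for less inhibition and higher numbers for more inhibition at the one concentration tested (going by the name of the read-out)), compound 1 gives "not determined" (no result reported), and compound 3 gives "not determined" (no result reported). Compound 2 `Cc1n[nH]c2ccc(-c3nc4cnc(N5CCN(C)CC5)cn4c3Nc3ccc(Br)cc3)cc12` is the one that does carry a number. In this assay compound 2 gives 11.7%, a small reading at the one concentration tested. Compound 3 therefore stands without a value of its own, and the only anchor for anything built from it is what compound 2 shows.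

Compound 4 `Cc1n[nH]c2ccc(-c3nc4cnc(N5CCN(C)CC5)cn4c3Nc3cc(Cl)ccc3Cl)cc12` has not yet been tested. The change from compound 3 to compound 4 is 2,5-dichlorophenyl in place of 4-bromo-2-chlorophenyl on a nitrogen on an aromatic ring. The group leaving and the group entering are alike in size and in ring, and differ only in the halogens they carry. Within the data shown here, with no measured step anywhere in this set, nothing points to a rise or a fall beyond the usual scatter, and the expectation is a reading much like that of compound 2. Compound 4 is estimated at 12% in this assay, with an expected range from 0% to 35%.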

Compound 4, a percentage reported as inhibition, at one concentration (the size of the read-out at that concentration, not a potency): 3.8%
Compound 4: the middle estimate sits 8.2 percentage points above what was measured; the range from low to high includes it.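

Among these compounds, the swap of 4-bromophenyl for 2,5-dichlorophenyl on this nitrogen gives a number 7.9 percentage points lower from compound 2 to compound 4 (within the scatter) in this assay, the first step that can be read at this position, and it shows no real difference between these two halogen-bearing rings. Compound 4, at 3.8%, thus joins compound 2 at the low end of the read-out, though two compounds are too few to make a pattern, and steps involving compound 1 or compound 3 cannot be read. Nothing measured here offers an explanation for these readings.

All the groups with a reading at this position are halogen-bearing phenyl rings. On these data alone, whether a phenyl ring carrying an amine or a carboxylic acid, or a longer alkyl chain in place of the ring, would give a clearly larger reading remains open.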